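The compounds below may be only part of what the source reports. "The series", "measured", "known", "first", "only" and "open" are said of these compounds alone.

Measured so far in a functional assay on G-361 cells (Homo sapiens) for cytotoxicity, read by fluorescence, with a stated time of 72 h; on this read-out higher numbers stand for weaker inhibition and lower numbers for stronger inhibition:
Compound 1 `CSc1nc(NCc2ccc(-c3ccccn3)cc2)c2[nH]nc(C(C)C)c2n1`: 1400 nM
Compound 2 `CC(C)c1n[nH]c2c(NCc3ccc(-c4ccccn4)cc3)nc(S(C)(=O)=O)nc12`: 793 nM

With only these two numbers available, compound 2 at 793 nM cannot be separated from compound 1 at 1400 nM, as the two values lie within the scatter of each other. The next compound to be tested is compound 3 `CC(C)c1n[nH]c2c(NCc3ccc(-c4ccccn4)cc3)nc(NCCO)nc12`. It carries (2-hydroxyethyl)amino in place of methylsulfonyl on an aromatic carbon, between two ring nitrogen atoms ((2-hydroxyethyl)amino in place of methylsulfonyl on an aromatic carbon).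

Within the data shown here, one measured step bears on this carbon, and it is small: a 1.8-fold lower number from compound 1 to compound 2 (0.25 log units; within the scatter). That step exchanged one sulfur-linked group for another, so it gives no size for the entry of an amino chain. Among the measured compounds shown here, no measured compound has such a chain at this carbon, and the direction is therefore only a tentative expectation. A moderate move towards a lower number in this assay is expected, with wide uncertainty that includes no change beyond the scatter. The estimated change is a 2.6-fold lower number from compound 2 to compound 3 (0.42 log units; beyond the scatter). For compound 3 the estimated value is 300 nM, with an expected range from 60 nM to 1200 nM.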

Compound 3, half-maximal inhibitory concentration: 39 nM
Estimate against measurement, compound 3: 7.7-fold (0.89 log units) above; the whole stated range lies above it.
By their numbers in this assay, from the lowest: compound 3; then compounds 2 and 1 (each within the scatter of the next).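

In this assay, this carbon, between two ring nitrogen atoms, turns out to be far more sensitive to its substituent than the exchange of one sulfur-linked group for another suggested: that exchange gave only a 1.8-fold lower number from compound 1 to compound 2 (0.25 log units; within the scatter), whereas (2-hydroxyethyl)amino in place of methylsulfonyl gives a 20-fold lower number from compound 2 to compound 3 (1.31 log units; beyond the scatter), and the same group in place of methylsulfanyl gives a 36-fold lower number from compound 1 to compound 3 (1.56 log units; beyond the scatter). Methylsulfonyl and (2-hydroxyethyl)amino each count 4 heavy atoms, so this large step comes with no change in that count, while the hydrogen-bond donors go from 0 to 2 and a nitrogen atom now links the group to the ring. Nothing available here explains why the number falls so far.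

The compounds shown leave open whether the step belongs to the linking nitrogen or to the terminal hydroxyl, and how much the length of the chain matters. A plain amine or a methylamino group on this carbon would address the first question, while a 3-hydroxypropylamino chain or a chain ending in a carboxylic acid would address the length and the end of the chain.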